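Stability in human liver microsomes across a benzyl swap

This account rests on a few compounds, and the source may have more. Where it says the series, first, only, none or still open, it means among the compounds named here.

Measured compounds:
compound 1 `CS(=O)(=O)Nc1ccc2c(c1)S(=O)(=O)N=C(C1=C(O)[C@@H]3[C@H]4CC[C@H](C4)[C@@H]3N(Cc3ccc(F)c(Cl)c3)C1=O)N2`: 87%
compound 2 `CS(=O)(=O)Nc1ccc2c(c1)S(=O)(=O)N=C(C1=C(O)[C@@H]3[C@H]4CC[C@H](C4)[C@@H]3N(Cc3ccc(F)c(F)c3F)C1=O)N2`: 100%
compound 3 `CS(=O)(=O)Nc1ccc2c(c1)S(=O)(=O)N=C(C1=C(O)[C@@H]3[C@@H]4CC[C@@H](C4)[C@@H]3N(Cc3ccc(F)c(Cl)c3)C1=O)N2`: 100%

In an ADME assay on microsomes from liver (Homo sapiens) for metabolic stability, with a stated time of 60 min, tested at 1 uM (a higher number here means that more of the compound is left, a lower number that less of the compound is left), compound 1 gives 87%. Compound 2 carries 2,3,4-trifluorophenyl in place of 3-chloro-4-fluorophenyl on a saturated chain carbon bound to an amide-type nitrogen in a ring, and this brings a number 13 percentage points higher from compound 1 to compound 2 (beyond the scatter). Compound 3 shares the atoms and bonds of compound 1 and differs only in configuration, namely (the two compounds have the same atoms and bonds and differ only in configuration as drawn: 2 of 4 stereo elements differ; a stereocentre at a saturated ring carbon is drawn S in compound 1 and R in compound 3; a stereocentre at a saturated ring carbon is drawn R in compound 1 and S in compound 3); this gives a number 13 percentage points higher from compound 1 to compound 3 (beyond the scatter), and the only thing that separates the two compounds is the fact that compounds 1 and 3 differ only in the configuration as drawn. Compound 3 and compound 2 stand level within the scatter, together at the top of the three values.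

Compound 4 `CS(=O)(=O)Nc1ccc2c(c1)S(=O)(=O)N=C(C1=C(O)[C@@H]3[C@@H]4CC[C@@H](C4)[C@@H]3N(Cc3ccc(F)c(F)c3F)C1=O)N2` is not yet measured. It carries 2,3,4-trifluorophenyl in place of 3-chloro-4-fluorophenyl on a saturated chain carbon bound to an amide-type nitrogen in a ring, the same change as between compound 1 and compound 2, at the same place. That earlier change gave a number 13 percentage points higher from compound 1 to compound 2 (beyond the scatter). From compound 3 to compound 4 a smaller step is expected, because compound 3 already gives 100%, so that the read-out leaves little room to rise. The expected step is a number 1 percentage points lower from compound 3 to compound 4 (within the scatter). For compound 4 in this assay the estimate is 99%, with a range from 90% to 100%.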

Compound 4, percent of the compound remaining: 87%
For compound 4 the middle estimate is 12 percentage points above the measured one; the measured number lies below the stated range.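

In this assay, 2,3,4-trifluorophenyl in place of 3-chloro-4-fluorophenyl gives a number 13 percentage points lower from compound 3 to compound 4 (beyond the scatter), so the change does not carry from one core to the other, and its direction is reversed: the same change on two cores in this assay, a number 13 percentage points higher (beyond the scatter) from compound 1 to compound 2 and a number 13 percentage points lower (beyond the scatter) from compound 3 to compound 4, 26 percentage points apart, beyond the scatter of two such steps. The change of configuration, read with the 2,3,4-trifluorobenzyl group, gives a number 13 percentage points lower from compound 2 to compound 4 (beyond the scatter), which runs opposite to the step seen with the 3-chloro-4-fluorobenzyl group, and nothing else separates these two compounds: the fact that compounds 2 and 4 differ only in the configuration as drawn. Within these four compounds, the outcome of the benzyl swap therefore depends on the configuration as drawn, but this does not show why it does, nor how the swap would behave on any other core, and two of the values lie at the top of the read-out.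

The compounds shown leave open whether an unsubstituted benzyl group or a pyridylmethyl group at the same place would show the same reversal between the two cores. They also leave open whether a benzyl group bearing a single fluorine would do so.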